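Aryl variation at the amine: compound 3 to compound 4

The source may report more compounds than this note shows. Statements on the series, on what has been measured and on what is new or still open speak of the compounds shown alone.

For the measured compounds named here, compound 3 `C=CC(=O)Nc1cccc(NC(=O)CSc2nc(Nc3cccc(Br)c3)c3ccccc3n2)c1` gives 15000 nM in a functional assay on PC-3 cells (Homo sapiens) for inhibition, read by MTT assay, with a stated time of 72 h (on this read-out higher numbers stand for weaker inhibition and lower numbers for stronger inhibition), the highest of the three numbers so far. Compound 2 `C=CC(=O)Nc1cccc(NC(=O)CSc2nc(Nc3cccc(F)c3)c3ccccc3n2)c1` gives 5370 nM and compound 1 `O=C(CSc1nc(Nc2ccccc2)c2ccccc2n1)Nc1ccc(F)cc1` gives 9560 nM; compound 3 lies within the scatter of compound 1 and beyond it relative to compound 2. Going by the values given here, the one measured step, a 2.8-fold higher number from compound 2 to compound 3 (0.45 log units; beyond the scatter), is the sole comparison available on the aryl group attached to this nitrogen. Compound 4 `C=CC(=O)Nc1cccc(NC(=O)CSc2nc(Nc3cc(OC)c(OC)c(OC)c3)c3ccccc3n2)c1` carries 3,4,5-trimethoxyphenyl in place of 3-bromophenyl on a nitrogen on an aromatic ring. Among the compounds with values here, no measured step exchanges a halogen for methoxy groups on this ring, so the direction of the change is not anchored. Compound 1, with an unsubstituted ring and without the acrylamide, gives a number within the scatter of compound 3, which suggests that this aryl ring shifts the number only modestly. The step in this assay is therefore expected to be modest, with no firm direction: the estimated step is a 1.5-fold lower number from compound 3 to compound 4 (0.18 log units; within the scatter). Compound 4 is expected to give about 10000 nM, with a range from 3000 nM to 30000 nM.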

Compound 4, half-maximal inhibitory concentration: > 50000 nM
Compound 4 gave a limit, no number; the forecaster's own chance of this, stated with the estimate: 10%; middle value at least 5.0-fold (0.69 log units) from the limit.
By their numbers in this assay, from the lowest: compounds 2, 1 and 3 (each within the scatter of the next, the first and the last beyond it). At a limit, above all of these: compound 4.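

In this assay compound 4 gives a limit and not a number: the limit of > 50000 nM in this assay, at which 1 of the 4 values shown sits.

Replacing either halogenated ring on this nitrogen with 3,4,5-trimethoxyphenyl gives an at least 3.3-fold higher number from compound 3 to compound 4 (0.52 log units; beyond the scatter) and an at least 9.3-fold higher number from compound 2 to compound 4 (0.96 log units; beyond the scatter), so both steps lie beyond the scatter and point the same way. The earlier compounds shown here covered only a halogen exchange at this position, a 2.8-fold higher number from compound 2 to compound 3 (0.45 log units; beyond the scatter), whereas these steps show that a ring carrying three methoxy groups also weakens inhibition on this read-out.

Since compound 4 gives only a limit, the full size of both steps remains unknown, and the compounds shown do not separate the contribution of each methoxy group. Also open, from the compounds shown here alone, is whether a single methoxy group or an amine on this ring would keep the number close to that of compound 2.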